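Replacing the aryl ether of compound 2 with a fluorobenzyl group

This account rests on a few compounds, and the source may have more. Where it says the series, first, only, none or still open, it means among the compounds named here.

Measured compounds in a functional assay for inhibition, with Homo sapiens as the target; a lower number here means tighter binding, a higher number weaker binding:
compound 1 `CSc1ccc(OC(C)(C)C2OCC(C/C=C\CCC(=O)O)C(c3cccnc3)O2)c([N+](=O)[O-])c1` gives 4.47 nM
compound 2 `COc1ccccc1OC(C)(C)C1OCC(C/C=C\CCC(=O)O)C(c2cccnc2)O1` gives 224 nM
compound 3 `COc1ccc(OC(C)(C)C2OCC(C/C=C\CCC(=O)O)C(c3cccnc3)O2)c([N+](=O)[O-])c1` gives 6.17 nM

Compound 2 stands as the weakest of the three, with a 36-fold lower number from compound 2 to compound 3 (1.56 log units; beyond the scatter) and a 50-fold higher number from compound 1 to compound 2 (1.70 log units; beyond the scatter) both beyond the scatter. Compound 4 `CC(C)(Cc1ccc(F)cc1)C1OCC(C/C=C\CCC(=O)O)C(c2cccnc2)O1` differs from compound 2 by 4-fluorobenzyl in place of 2-methoxyphenoxy on a saturated chain carbon bound to two saturated chain carbons and a saturated ring carbon. The two measured steps at this position show that the group attached here matters greatly, but neither removes the ether oxygen or introduces a halogen, so no direct guide exists. In this assay the expectation for compound 4 is therefore a small change, a 1.3-fold higher number from compound 2 to compound 4 (0.13 log units; within the scatter), with wide uncertainty. Compound 4 is estimated at 300 nM, between 50 nM and 2000 nM.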

Compound 4, dissociation constant: 89.1 nM
Beside the measured number, compound 4's estimate is 3.4-fold (0.53 log units) above it; low and high end bracket the measured number.
By their numbers in this assay, from the lowest: compounds 1 and 3 (each within the scatter of the next); then compound 4; then compound 2.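

In this assay, putting 4-fluorobenzyl on this saturated chain carbon gives a 2.5-fold lower number from compound 2 to compound 4 (0.40 log units; beyond the scatter). The number thus does not rise when 2-methoxyphenoxy, with its two hydrogen-bond acceptors, gives way to a group with none, so those acceptors are not required for the value of compound 2. The compounds shown leave open whether the fluorine itself contributes, and whether chlorine or an unsubstituted benzyl would do the same. Nothing available explains this step.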